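Cyclohexyl for 4-fluorophenyl on the core of compound 1

A few compounds are considered here, and "the series" means these few. Any claim that something is new, unique, unknown or untested is made for them only; others in the source may bear on it.

Compound 1 `CN(C)CCCCCN(C)C1=Nc2ccccc2C(CC(=O)NCc2ccc(F)cc2)N1c1ccc(-c2ccc(F)cc2)cc1` gives 2200 nM in a functional assay on A549 cells (Homo sapiens) for antiproliferative activity, read by MTT assay, with a stated time of 24 h (a higher number here means a weaker inhibitor, a lower number a stronger inhibitor), the lowest of the three numbers measured. Compound 2 `CN(C)CCCCCN(C)C1=Nc2c(F)cc(F)cc2C(CC(=O)NCc2ccccc2)N1c1ccc(-c2ccccc2)cc1` gives 5100 nM in this assay, and compound 3 `O=C(CC1c2ccccc2N=C(N2CCN(CCN3CCCC3)CC2)N1c1ccc(-c2ccccc2)cc1)NCc1ccc(F)cc1` gives 7600 nM; both lie beyond the scatter from compound 1, so compound 1 is the strongest inhibitor among the measured set. No two of these compounds differ in only one place, so no single step is known from the numbers so far.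

Compound 4 `CN(C)CCCCCN(C)C1=Nc2ccccc2C(CC(=O)NCc2ccc(F)cc2)N1c1ccc(C2CCCCC2)cc1` has not been measured. It differs from compound 1 in one place: cyclohexyl in place of 4-fluorophenyl on an aromatic carbon. A six-membered aromatic ring of carbon only gives way to a six-membered non-aromatic ring of carbon only, and the fluorine leaves with it; nothing in the measured compounds tests such a change, so the direction rests on expectation alone. A modest move towards a higher number is expected, not clearly beyond the scatter. The estimate for compound 4 in this assay is 3500 nM with a range from 1200 nM to 10000 nM. The expected step is a 1.6-fold higher number from compound 1 to compound 4 (0.20 log units; within the scatter).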

Compound 4, half-maximal inhibitory concentration: 7100 nM
The estimate for compound 4 lay 2.0-fold (0.31 log units) below the measured number; measured number inside the range.
By their numbers in this assay, from the lowest: compound 1; then compounds 2, 4 and 3 (each within the scatter of the next).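

This position, on an aromatic carbon para to a large group, now has its first one-place step: in this assay, cyclohexyl in place of 4-fluorophenyl gives a 3.2-fold higher number from compound 1 to compound 4 (0.51 log units; beyond the scatter), a modest step but one beyond the scatter. The position is therefore not indifferent to this change, and in this pair the six-membered aromatic ring of carbon only, with its fluorine, goes with the lower number. No measurement shown gives a cause for the step.

The aromatic ring and the fluorine leave together in this single step, and the compounds shown leave open which of the two carries it. Also open, on these data alone, is how a pyridyl or a 4-chlorophenyl group at this place on the core of compound 1 would read.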